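Butyl ester follows isopropyl on a shared core

The compounds below may be only part of what the source reports. "The series", "measured", "known", "first", "only" and "open" are said of these compounds alone.

Measured so far:
compound 1 `CCCOC(=O)[C@@]12C[C@@H]1[C@@H](n1cnc3c(NC)nc(C#Cc4ccc(Cl)s4)nc31)[C@H](O)[C@@H]2O` — 5.78 nM
compound 2 `CNc1nc(C#Cc2ccc(Cl)s2)nc2c1ncn2[C@H]1[C@H](O)[C@H](O)[C@]2(C(=O)OC(C)C)C[C@H]12` — 42.9 nM

Two esters of the shared core have been tested in an assay on HEK-293T cells for displacement of a labelled ligand from transmembrane domain-containing protein TMIGD3 (Homo sapiens), read by scintillation counting and radioligand binding, with stated times of 10 min and 90 min; a lower number here means a stronger inhibitor, a higher number a weaker inhibitor. Compound 1 gives 5.78 nM there, and compound 2 gives 42.9 nM. Compound 2 stands highest of the two numbers; its nearest neighbour is compound 1, and the step of a 7.4-fold higher number from compound 1 to compound 2 (0.87 log units; beyond the scatter) is modest but beyond the scatter.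

Compound 3 `CCCCOC(=O)[C@@]12C[C@@H]1[C@@H](n1cnc3c(NC)nc(C#Cc4ccc(Cl)s4)nc31)[C@H](O)[C@@H]2O` has not yet been measured. It differs from compound 2 by butyl in place of isopropyl on an oxygen next to a carbonyl group. Among the compounds with values here, the only measured step that bears on this change is a 7.4-fold higher number from compound 1 to compound 2 (0.87 log units; beyond the scatter), which shows a propyl ester giving a lower number than an isopropyl ester. Butyl, like propyl, is an unbranched chain, so compound 3 is expected to move back toward the number of compound 1, a downward step of a 4.8-fold lower number from compound 2 to compound 3 (0.68 log units; beyond the scatter), though no measured step covers the longer chain itself. Compound 3 is therefore estimated at 9 nM, within a range from 3 nM to 35 nM.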

Compound 3, inhibition constant: 17.5 nM
Compound 3: the middle estimate sits 1.9-fold (0.29 log units) below what was measured, and the stated range covers the measured number.
By their numbers in this assay, from the lowest: compound 1; then compound 3; then compound 2.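

In this assay, butyl in place of isopropyl on an oxygen next to a carbonyl group gives a 2.5-fold lower number from compound 2 to compound 3 (0.39 log units; beyond the scatter), so among these esters the unbranched butyl chain recovers part of what the isopropyl ester lost. That recovery is only partial: methyl in place of hydrogen at the end of the propyl chain gives a 3.0-fold higher number from compound 1 to compound 3 (0.48 log units; beyond the scatter), which shows that this position responds to chain length as well as to branching. Nothing available explains either difference.

The compounds shown leave open whether a longer chain such as pentyl would raise the number further, and whether the shorter methyl and ethyl esters would fall below the propyl ester. They also leave open how a carboxylic acid or an amide would behave in this place.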